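Toward a Benzothiophene Sulfonamide in the Same Series

A few compounds are considered here, and "the series" means these few. Any claim that something is new, unique, unknown or untested is made for them only; others in the source may bear on it.

Of the compounds shown here, three sharing one core have been tested in a functional assay on MIA PaCa-2 cells (Homo sapiens) for inhibition, read by MTT assay, with a stated time of 72 h; on this read-out lower numbers stand for stronger inhibition of growth and higher numbers for weaker inhibition of growth. Compound 1 `Cc1ccc(C)c(S(=O)(=O)NCCCCCCNCc2ccc(Br)cc2)c1` gives 12000 nM, compound 2 `O=S(=O)(NCCCCCCNCc1ccc(Br)cc1)c1ccccc1Cl` gives 13700 nM, and compound 3 `O=S(=O)(NCCCCCCNCc1ccc(Br)cc1)c1ccc(Cl)cc1` gives 5900 nM. Compound 3 thus stands at the lowest number of the three; the two other numbers lie apart from it, as a 2.0-fold lower number from compound 1 to compound 3 (0.31 log units; beyond the scatter) and a 2.3-fold lower number from compound 2 to compound 3 (0.37 log units; beyond the scatter), whereas a 1.1-fold higher number from compound 1 to compound 2 (0.06 log units; within the scatter). Compound 4 `O=S(=O)(NCCCCCCNCc1ccc(Br)cc1)c1ccc2ccsc2c1` has not yet been measured in this assay. It differs from compound 3 in one place: 1-benzothiophen-6-yl in place of 4-chlorophenyl on a sulfonyl sulfur. Among the compounds with values here, no measured step brings in a group with one five-membered aromatic ring with 1 hetero atom, so the three swaps of the aryl group on the sulfonyl sulfur, each modest or within the scatter, are the only guide. Compound 4 is therefore expected to give a number not far from that of compound 3, the estimated step being a 1.5-fold lower number from compound 3 to compound 4 (0.17 log units; within the scatter). The estimate for compound 4 in this assay is 4000 nM, with a range from 1500 nM to 10000 nM.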

Compound 4, concentration for 50% growth inhibition: 6000 nM
Compound 4: the middle estimate sits 1.5-fold (0.18 log units) below what was measured; the range from low to high includes it.
By their numbers in this assay, from the lowest: compounds 3, 4, 1 and 2 (each within the scatter of the next, the first and the last beyond it).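

In this assay, the 1-benzothiophen-6-yl group stands level with the 4-chlorophenyl group on the sulfonyl sulfur, a 1.0-fold higher number from compound 3 to compound 4 (0.01 log units; within the scatter), so this position takes a group with a five-membered aromatic ring and a six-membered aromatic ring without leaving the scatter. Against the two other aryl groups, the same change gives a 2.3-fold lower number from compound 2 to compound 4 (0.36 log units; beyond the scatter), beyond the scatter, and a 2.0-fold lower number from compound 1 to compound 4 (0.30 log units; within the scatter), within it, so the new group sits clearly apart only from the 2-chlorophenyl group. Nothing shown here offers a reason for these results.

The compounds shown leave open whether an aryl group carrying a carboxylic acid or an amine would keep the number of compound 3. They also leave open what a longer chain in the shared core would do.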